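Removing the 4-fluorophenyl group from the ring amide nitrogen

A few compounds are considered here, and "the series" means these few. Any claim that something is new, unique, unknown or untested is made for them only; others in the source may bear on it.

Measured in a functional assay on HCT-116 cells (Homo sapiens) for antiproliferative activity, read by MTT assay, with a stated time of 72 h; on this read-out lower numbers stand for stronger inhibition and higher numbers for weaker inhibition:
compound 1, `COc1ncc(-c2ccc3c(c2)NC(=O)CO3)cc1NS(=O)(=O)c1ccc(F)cc1`: 24900 nM
compound 2, `COc1ncc(-c2ccc3c(c2)N(c2ccc(F)cc2)C(=O)CO3)cc1NS(=O)(=O)c1ccc(F)cc1`: > 40000 nM, a limit of the assay
compound 3, `O=C1COc2ccc(-c3cnc4ccccc4c3)cc2N1c1ccc(F)cc1`: > 40000 nM, a limit of the assay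

In this assay compound 1 gives 24900 nM. For compound 2 the value > 40000 nM is a limit of the assay and not a number. For compound 3 the value > 40000 nM is likewise a limit. Among these three, (the limit of > 40000 nM in this assay, at which 2 of the 3 values shown sit). The change from compound 2 to compound 1 is hydrogen in place of 4-fluorophenyl on an amide-type nitrogen in a ring, and it made an at least 1.6-fold lower number from compound 2 to compound 1 (0.20 log units; that floor lies within the scatter). How the core of compound 3 differs from the core of compound 2 is not broken down here.

Compound 4, `O=C1COc2ccc(-c3cnc4ccccc4c3)cc2N1`, is not yet measured. It arises from compound 3 by the same change, (hydrogen in place of 4-fluorophenyl on an amide-type nitrogen in a ring). The step from compound 3 to compound 4 is expected to be about an at least 1.3-fold lower number from compound 3 to compound 4 (0.12 log units; that floor lies within the scatter) because the same change once gave an at least 1.6-fold lower number from compound 2 to compound 1 (0.20 log units; that floor lies within the scatter). Compound 4 is therefore estimated at 30000 nM, somewhere from 10000 nM to 90000 nM, with a real chance that only a limit is reported.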

Compound 4, half-maximal inhibitory concentration: > 40000 nM
Compound 4: a limit, no number; the forecaster's own chance of this, stated with the estimate: 45%; middle value at least 1.3-fold (0.12 log units) from the limit.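

Compound 4 gives > 40000 nM, a limit of the assay and not a number. Compound 3 also has only a limit, so the step between compound 3 and compound 4 cannot be read. The compounds shown leave open whether hydrogen in place of 4-fluorophenyl changes the activity of the core of compound 3 at all.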